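Adding Amino to a Compound at the Assay Limit

The source may report more compounds than this note shows. Statements on the series, on what has been measured and on what is new or still open speak of the compounds shown alone.

Compound 1 (`CCn1cc(-c2nc3ccccc3[nH]2)c(=O)c2cc(F)c(N3CCNCC3)nc21`) was tested in a functional assay on PC-3 cells (Homo sapiens) for cytotoxicity, read by sulforhodamine B assay, with a stated time of 48 h; on this read-out higher numbers stand for weaker inhibition of growth and lower numbers for stronger inhibition of growth. Compound 1 gives > 10000 nM, which is a limit of the assay and not a number. Its place on the scale is therefore only this: the limit of > 10000 nM in this assay, at which 1 of the 3 values shown sits.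

Two other compounds give numbers but differ from compound 1 in more than one place. Compound 2 (`CCn1cc(-c2nc3ccc([N+](=O)[O-])cc3o2)c(=O)c2cc(F)c(N3CCNC(C)C3)c(F)c21`) gives 3300 nM and compound 3 (`CCn1cc(-c2nc3ccc([N+](=O)[O-])cc3s2)c(=O)c2cc(F)c(N3CCNC(C)C3)c(F)c21`) gives 2700 nM, two values within the scatter of each other.

Compound 4 (`CCn1cc(-c2nc3ccc(N)cc3[nH]2)c(=O)c2cc(F)c(N3CCNCC3)nc21`) carries amino in place of hydrogen on an aromatic carbon of a six-membered aromatic ring of carbon only (amino in place of hydrogen on an aromatic carbon). Within the data shown here, no measured pair shows this change in this assay. A modest move toward stronger inhibition of growth is expected, one that stays on the weak side of compound 3 with 2700 nM. Estimated in size, the expected step is an at least 1.2-fold lower number from compound 1 to compound 4 (0.09 log units; that floor lies within the scatter). For compound 4 the estimated value is 8000 nM, with an expected range from 3000 nM to 20000 nM.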

Compound 4, concentration for 50% growth inhibition: > 10000 nM
Compound 4: only a limit was reported; the forecaster's own chance of this, stated with the estimate: 55%; middle value at least 1.2-fold (0.09 log units) away from the limit.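

In this assay compound 4 gives > 10000 nM, which is a limit of the assay and not a number. Among these compounds, compound 1 also stands at a limit, so no step between compound 1 and compound 4 can be read. The compounds shown leave open whether amino in place of hydrogen on an aromatic carbon changes growth inhibition at all.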